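Cyclobutyl Amine Variations on a Nitrile Kinase Scaffold

The source may report more compounds than this note shows. Statements on the series, on what has been measured and on what is new or still open speak of the compounds shown alone.

For the measured compounds named here, compound 1, `N#Cc1cnc(NCc2cnccc2C(F)(F)F)cc1N[C@H]1C[C@@H](O)C1`, is one of two compounds measured in an assay on isolated protein for inhibition of protein kinase C theta type (Homo sapiens), read by TR-FRET, with a stated time of 2 h (on this read-out higher numbers stand for weaker inhibition and lower numbers for stronger inhibition), where compound 1 gives 500 nM. The other, compound 2, `CC1(C)[C@@H](Nc2nc(NCc3cnccc3C(F)(F)F)ncc2C#N)C[C@@H]1O`, gives 170 nM in this assay, so compound 1 carries the higher of the two numbers, and the gap between them lies beyond the usual scatter. Compound 2 is built on a different core, so its value speaks only for itself.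

The next compound, compound 3, `CC1(C)[C@@H](Nc2cc(NCc3cnccc3C(F)(F)F)ncc2C#N)C[C@H]1C(N)=O`, keeps the core of compound 1 and changes the amine substituent: 3-carbamoyl-2,2-dimethylcyclobutyl in place of 3-hydroxycyclobutyl on a nitrogen on an aromatic ring. Going by the values given here, no measured pair shows this exact change. Compound 3 is therefore expected to give a number near that of compound 1, with a step of a 1.7-fold lower number from compound 1 to compound 3 (0.22 log units; within the scatter) in this assay that stays within the scatter or at most slightly lowers the number. The estimate for compound 3 in this assay is 300 nM, with a range from 100 nM to 900 nM.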

Compound 3, half-maximal inhibitory concentration: 140 nM
Compound 3: the middle estimate sits 2.1-fold (0.33 log units) above what was measured; the range from low to high includes it.
By their numbers in this assay, from the lowest: compounds 3 and 2 (each within the scatter of the next); then compound 1.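

Moving from 3-hydroxycyclobutyl to 3-carbamoyl-2,2-dimethylcyclobutyl on the nitrogen on an aromatic ring gives the first readable step on the core of compound 1 in this assay, with a 3.6-fold lower number from compound 1 to compound 3 (0.55 log units; beyond the scatter). This position therefore accepts a substituent of 9 heavy atoms in place of one of 5, and inhibition strengthens rather than weakens with this change. No supporting measurement bears on why the number falls.

The change brings in the carbamoyl and the 2,2-dimethyl groups together, so the compounds shown leave open how much of the step belongs to each on this core. They also leave open how a carboxylic acid or an amine in place of the carbamoyl would read.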